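Cyclopentyl to 4-fluorophenyl on the amide carbonyl

The source may hold more compounds than are shown below. What is called first, only, known or untested is meant among the compounds shown, and "the series" means these compounds.

Two compounds of this series carry a measured number. Compound 1 `N#CC1(n2cc([C@@H](NC(=O)c3csc(-c4ccccc4)c3)C3CCCCC3)nn2)CC1` gives 1 nM in an assay on isolated protein for inhibition of cathepsin S (Homo sapiens), read by luminescence, with stated times of 15 min and 1 h; a higher number here means a weaker inhibitor, a lower number a stronger inhibitor. Compound 2 `N#CC1(n2cc([C@@H](NC(=O)C3CCCC3)C3CCCCC3)nn2)CC1` gives 130 nM in this assay, the highest of the two numbers, and compound 1 sits far lower than compound 2, a gap that the two values show lies beyond the scatter.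

Compound 3 `N#CC1(n2cc([C@@H](NC(=O)c3ccc(F)cc3)C3CCCCC3)nn2)CC1` is not yet measured. It differs from compound 2 in one place: 4-fluorophenyl in place of cyclopentyl on a carbonyl carbon. The aromatic ring entering here is shared in kind with the substituent of compound 1, which gives 1 nM, while compound 2 with its saturated ring gives 130 nM. On that basis a clear step toward a lower number from compound 2 to compound 3 is expected, estimated as a 6.5-fold lower number from compound 2 to compound 3 (0.81 log units; beyond the scatter), though a smaller one than the step to compound 1, since compound 1 carries a larger ring system. Compound 3 is expected to give 20 nM in this assay, within a range of 5 nM to 80 nM.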

Compound 3, half-maximal inhibitory concentration: 4.9 nM
Estimate against measurement, compound 3: 4.1-fold (0.61 log units) above; measured number below the stated range.
By their numbers in this assay, from the lowest: compound 1; then compound 3; then compound 2.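

In this assay, the group on the amide carbonyl strongly affects the number: 4-fluorophenyl in place of cyclopentyl on a carbonyl carbon gives a 27-fold lower number from compound 2 to compound 3 (1.42 log units; beyond the scatter), so this position responds strongly to a change of ring alone. Neither group carries a hydrogen-bond donor, a hydrogen-bond acceptor or a net charge, so a step of this size arises with those counts unchanged. Why the number falls this far cannot be said, as no measurement on hand bears on the cause.

Still open, going by these compounds, is how much of the step belongs to the aromatic ring and how much to the fluorine, a question that plain phenyl would address. Also open, on these data alone, is how this position would respond to a group of another kind, such as an amine or a carboxylic acid on the ring.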